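The source may report more compounds than this note shows. Statements on the series, on what has been measured and on what is new or still open speak of the compounds shown alone.

Measured so far in an assay for inhibition of protein disulfide-isomerase (Homo sapiens), with a stated time of 1 h; a lower number here means a stronger inhibitor, a higher number a weaker inhibitor:
compound 1 `Cc1ccnc(NC(c2ccc(C(F)(F)F)cc2)c2ccc3cccnc3c2O)c1` gives 26500 nM
compound 2 `Oc1c(C(c2ccc(F)cc2)N2CCCCC2)ccc2cncnc12` gives 4860 nM

Compound 1 holds the highest of the two numbers. Its nearest neighbour is compound 2, whose number is lower by a margin beyond the usual scatter of this assay. Among the compounds with values here, no one-place step joins compound 1 to compound 2, so nothing more can be drawn from that pair than what the two values show.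

The unmeasured compound 3 `Cc1ccnc(NC(c2ccccc2F)c2ccc3cccnc3c2O)c1` differs from compound 1 in a single place: 2-fluorophenyl in place of 4-(trifluoromethyl)phenyl on a saturated chain carbon bound to an aromatic carbon and a nitrogen on an aromatic ring. The shared core of compound 1 is kept unchanged, as is the nitrogen on an aromatic ring bound to the saturated chain carbon. Within the data shown here, no measured pair in this set isolates such an exchange, so no step size can be read off from data; the expectation is for a step of modest size, if any, with no firm direction, and one that may well lie within the scatter. Compound 3 is estimated at 20000 nM (6000 nM to 60000 nM). The expected step in this assay is a 1.3-fold lower number from compound 1 to compound 3 (0.12 log units; within the scatter).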

Compound 3, half-maximal inhibitory concentration: 880 nM
Compound 3: middle estimate off by 23-fold (1.36 log units), on the high side; measured number below the stated range.
By their numbers in this assay, from the lowest: compound 3; then compound 2; then compound 1.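

The aryl group on the saturated chain carbon bound to an aromatic carbon and a nitrogen on an aromatic ring is a position that matters in this assay: with the shared core kept, 2-fluorophenyl in place of 4-(trifluoromethyl)phenyl gives a 30-fold lower number from compound 1 to compound 3 (1.48 log units; beyond the scatter). Within the data shown here, this is the first one-place step, which compound 1 and compound 2 could not provide, and it shows a large change in the number while the six-membered aromatic ring of carbon stays, with hydrogen-bond donor and acceptor counts and net charge equal on both sides. No measured evidence on the two compounds bears on the origin of this step.

The exchange removes a trifluoromethyl group and introduces a fluorine at once, so the shown compounds do not separate the loss of one from the gain of the other; unsubstituted phenyl, 2-(trifluoromethyl)phenyl or 2-chlorophenyl at this position would be needed to tell these apart. Also open, on these data alone, is whether a methoxy group or an amine on this aryl ring would fit the same trend, and whether the step holds on other cores.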